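Fluoro for Chloro: Expecting a Value for Compound 4

A few compounds are considered here, and "the series" means these few. Any claim that something is new, unique, unknown or untested is made for them only; others in the source may bear on it.

Compound 1, `COC(=O)[C@@]1(C)CCC=C2[C@@H]1CC[C@@H](C)[C@]2(C)Cc1c[nH]c2ccc(Cl)cc12`, gives 16000 nM in a functional assay on A549 cells (Homo sapiens) for inhibition, read by sulforhodamine B assay, with a stated time of 48 h; a higher number here means a weaker inhibitor of growth, a lower number a stronger inhibitor of growth.
Compound 2, `COC(=O)[C@@]1(C)CCC=C2[C@@H]1CC[C@@H](C)[C@]2(C)Cc1c[nH]c2ccc(F)cc12`, gives 6200 nM in this assay.
Compound 3, `COC(=O)[C@@]1(C)CC[C@@H]2C3=C1CC[C@@H](C)[C@]3(C)C[C@@H]1c3cc(Cl)ccc3N[C@H]21`, gives 35000 nM in this assay.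

Compounds 1 and 2 share one core and differ in a single spot: fluoro in place of chloro on an aromatic carbon. That change gave a 2.6-fold lower number from compound 1 to compound 2 (0.41 log units; beyond the scatter), so the fluoro compound was the stronger inhibitor of growth of the pair.

Compound 3 carries a different core built from the same atoms; how the two cores differ is not broken down here. Among the three measured compounds, compound 3 gives the highest number in this assay.

Compound 4, `COC(=O)[C@@]1(C)CC[C@@H]2C3=C1CC[C@@H](C)[C@]3(C)C[C@@H]1c3cc(F)ccc3N[C@H]21`, has not yet been measured. It relates to compound 3 the way compound 2 relates to compound 1: fluoro in place of chloro on an aromatic carbon. The surroundings are not identical, though: in compounds 1 and 2 the ring bearing the halogen is part of a fused or bridged system of two rings, while in compounds 3 and 4 it is part of a fused or bridged system of five rings, so this is the same kind of change rather than the same change.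

For the measured compounds named here, with only one earlier example to lean on, compound 4 is expected to show a step of about a 2.5-fold lower number from compound 3 to compound 4 (0.40 log units; beyond the scatter) in this assay, similar in size to the earlier one, because that earlier swap gave a 2.6-fold lower number from compound 1 to compound 2 (0.41 log units; beyond the scatter). The estimate for compound 4 is 14000 nM, with a likely range from 6000 nM to 35000 nM, the range kept wide since the core differs.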

Compound 4, concentration for 50% growth inhibition: 25000 nM
For compound 4 the middle estimate is 1.8-fold (0.25 log units) below the measured one; the range from low to high includes it.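

In this assay, the swap of chloro for fluoro on the five-ring core gives a 1.4-fold lower number from compound 3 to compound 4 (0.15 log units; within the scatter), so on this core the two halogens cannot be told apart by this measurement. On the two-ring side the same swap gave a step beyond the scatter, yet the two steps do not truly separate, and they are best read as compatible with one shared effect of modest size: the same change on two cores in this assay, a 2.6-fold lower number (0.41 log units; beyond the scatter) from compound 1 to compound 2 and a 1.4-fold lower number (0.15 log units; within the scatter) from compound 3 to compound 4, 1.8-fold (0.27 log units) apart, within the scatter of two such steps. This shows that nothing here argues against carrying the change from one core to the other, but it does not show that the change carries over with a fixed size, since two pairs are too few for that and the second step alone cannot be told from repeat-measurement noise.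

The compounds shown leave open how other groups on that same aromatic carbon would behave, such as bromo, methoxy or a nitrile, or plain hydrogen with no halogen at all. They also leave open whether replacing the methyl ester with a carboxylic acid or an amide would shift growth inhibition on either core, and whether the halogen swap would then give a step of similar size.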